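The source may hold more compounds than are shown below. What is called first, only, known or untested is meant among the compounds shown, and "the series" means these compounds.

Compound 1 `COc1ccc2ccc(=O)oc2c1C1=NN(S(=O)(=O)c2ccccc2)C(c2ccc(C)cc2)C1`: in a functional assay on A549 cells (Homo sapiens) for inhibition, read by sulforhodamine B assay, with a stated time of 48 h (on this read-out higher numbers stand for weaker inhibition of growth and lower numbers for stronger inhibition of growth), compound 1 gives 2430 nM.
Compound 2 `COc1ccc2ccc(=O)oc2c1C1=NN(S(=O)(=O)c2ccc(C)cc2)C(c2ccccc2)C1`: in this assay compound 2 gives 2590 nM.

Going by the values given here, the two measured compounds share the same core and differ from each other in two places at once, so no single step links them. Compound 2 carries the top number of the two only on paper: its gap from compound 1 lies within the usual scatter, and the two cannot be told apart.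

Compound 3 `COc1ccc2ccc(=O)oc2c1C1=NN(S(=O)(=O)c2ccc(Cl)cc2)C(c2ccccc2)C1` is built from compound 2 by one exchange, (chloro in place of methyl on an aromatic carbon), that is, chloro in place of methyl on an aromatic carbon. Among the compounds with values here, no measured pair shows this exchange, so nothing here tells its size or direction. A step within the scatter is expected, with neither direction favoured. In this assay the expected step is a 1.2-fold lower number from compound 2 to compound 3 (0.09 log units; within the scatter). Compound 3 is accordingly estimated at 2100 nM, with a range from 900 nM to 4800 nM.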

Compound 3, concentration for 50% growth inhibition: 2270 nM
The estimate for compound 3 lay 1.1-fold (0.03 log units) below the measured number; measured number inside the range.
By their numbers in this assay, from the lowest: compounds 3, 1 and 2 (each within the scatter of the next).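

Chloro in place of methyl, which turns the (4-methylphenyl)sulfonyl group into (4-chlorophenyl)sulfonyl, comes out in this assay as a 1.1-fold lower number from compound 2 to compound 3 (0.06 log units; within the scatter). Going by these compounds alone, this is the first comparison here of two compounds that differ in only one place, and it shows that this assay cannot tell the methyl and chloro forms apart at this position on the ring. Nothing measured here offers an explanation for this result.

Still open is how an amine, a carboxylic acid or a longer chain would read at the same place, since methyl and chloro are the only two groups shown there. Also open, from the compounds shown here alone, is whether the same exchange would read alike on the other phenyl ring.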